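Cytotoxicity notes on a benzoxazinone series: one open step

The source may report more compounds than this note shows. Statements on the series, on what has been measured and on what is new or still open speak of the compounds shown alone.

Measured compounds:
compound 1 `O=C1Oc2ccccc2N/C1=C\C(=O)c1ccncc1`: > 1870000 nM
compound 2 `COC(=O)/C=C1\Nc2ccccc2OC1O`: "not determined" (no result reported)

In an ADME assay on Vero cells (Chlorocebus sabaeus) for cytotoxicity, read by MTT assay, with a stated time of 72 h (on this read-out higher numbers stand for lower toxicity in this test and lower numbers for higher toxicity in this test), compound 1 returns only a limit, > 1870000 nM, not a number. Compound 2 has no result in this assay. Where compound 1 stands is therefore set by the limit alone: the limit of > 1870000 nM in this assay, at which 1 of the 2 values shown sits, with the other entry carrying no value. Going by the values given here, no step between two measured compounds can be drawn from this.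

Compound 3 `COC(=O)/C=C1\Nc2ccccc2OC1=O` is the next compound for this assay. It differs from compound 1 in one place: methoxy in place of pyridin-4-yl on a carbonyl carbon, the carbonyl carbon whose other neighbour is a double-bonded chain carbon.

With compound 1 sitting at the limit, no direction can be read from the data, and the step expected in this assay, a number no higher from compound 1 to compound 3 (the limit leaves the size open), is none beyond the scatter. Compound 3 is accordingly estimated to give about 1870000 nM, within a range from 400000 nM to 5000000 nM, with a fair chance that this assay again reports only a limit.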

Compound 3, half-maximal cytotoxic concentration: > 2280000 nM
Compound 3 was reported as a limit (the forecaster's own chance of this, stated with the estimate: 65%); middle value at least 1.2-fold (0.08 log units) away from the limit.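

No new step can be read: in this assay compound 1 and compound 3 are both reported only as limits, and the exchange of pyridin-4-yl for methoxy on a carbonyl carbon stays unreadable. The compounds shown leave open where the half-maximal cytotoxic concentration of either compound lies, and whether that exchange shifts it at all.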